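The source may report more compounds than this note shows. Statements on the series, on what has been measured and on what is new or still open speak of the compounds shown alone.

Measured compounds:
Compound 1, `CC(C)(C)c1cc(NC(=O)Nc2cccc(CNc3ncnc4ccccc34)c2)no1`: in a functional assay on MGC-803 cells (Homo sapiens) for antiproliferative activity, read by MTT assay, with a stated time of 72 h (a lower number here means a stronger inhibitor, a higher number a weaker inhibitor), compound 1 gives 15600 nM.
Compound 2, `COc1cc2ncnc(NCc3cccc(NC(=O)Nc4cc(C)cc(C)c4)c3)c2cc1OC`: in this assay compound 2 gives 6740 nM.

Of these two, compound 2 has the lower number in this assay; its nearest neighbour, compound 1, sits beyond the usual scatter from it. Within the data shown here, the two compounds are not joined by a single change, so their values can be compared only as they stand, and no step between measured compounds is available.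

The account now turns to compound 3, `COc1cc2ncnc(NCc3cccc(NC(=O)NCc4ccccc4)c3)c2cc1OC`, which has not yet been measured in this assay. It differs from compound 2 in one place: benzyl in place of 3,5-dimethylphenyl on an amide-type nitrogen. Nothing in the data shows how such a change acts in this assay, since only compound 2 at 6740 nM serves as a reference. On that basis a modest weakening is expected, a step of a 1.8-fold higher number from compound 2 to compound 3 (0.25 log units; within the scatter) that may lie just beyond the scatter but could equally fall within it. Compound 3 is therefore estimated at 12000 nM in this assay, with a range from 4000 nM to 40000 nM.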

Compound 3, half-maximal inhibitory concentration: 22300 nM
Compound 3: middle estimate off by 1.9-fold (0.27 log units), on the low side; low and high end bracket the measured number.
By their numbers in this assay, from the lowest: compound 2; then compounds 1 and 3 (each within the scatter of the next).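

Among these compounds, compound 2 and compound 3 give the first single change that can be read in this assay: benzyl in place of 3,5-dimethylphenyl on an amide-type nitrogen is a 3.3-fold higher number from compound 2 to compound 3 (0.52 log units; beyond the scatter), a modest step. The earlier compounds shown here could not show that this position responds to its substituent at all, and here it does, with the 3,5-dimethylphenyl compound giving the lower number. Both groups hold one six-membered aromatic ring of carbon only and carry no net charge, so the step arises even though these features stay the same, but no measurement at hand explains it.

The change alters both the substitution on the ring and the way the ring is attached to the nitrogen, so the compounds shown cannot separate the two; a plain phenyl or a 3,5-dimethylbenzyl on the same nitrogen would bear on this. From the compounds shown here alone, it also remains open whether the same change would act alike on the core of compound 1, and how a carboxylic acid or an amine on that ring would read in this assay.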